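The source may hold more compounds than are shown below. What is called first, only, known or untested is meant among the compounds shown, and "the series" means these compounds.

Two compounds have already been run in an assay on isolated protein for displacement of a labelled ligand from 5-hydroxytryptamine receptor 6 (Homo sapiens); a lower number here means a stronger inhibitor, a higher number a weaker inhibitor. Compound 1, with structure `Cn1ccc(S(=O)(=O)c2ccc3c(c2)CCC[C@H]3CN)c1`, carries a free amine on its side chain and gives 7.94 nM in this assay. Compound 2, with structure `O=C1CN=C(NC[C@@H]2CCCc3cc(S(=O)(=O)c4cccc(F)c4)ccc32)N1`, has that amine built into a larger ring-bearing group and gives 0.1 nM in this assay. Of the two numbers shown, compound 2 has the lower one, and the gap between compound 2 and compound 1 lies well beyond the usual scatter, so compound 2 is the stronger binder of the pair.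

Compound 3, with structure `COCCNC[C@@H]1CCCc2cc(S(=O)(=O)c3cccc(F)c3)ccc21`, is the next compound to be measured. It differs from compound 2 in one place: a group of 4 heavy atoms (3 carbon, 1 oxygen; no ring) in place of a group of 6 heavy atoms (3 carbon, 2 nitrogen, 1 oxygen; one five-membered non-aromatic ring with 2 hetero atoms), on an amine nitrogen.

Going by the values given here, no step between measured compounds describes this exact change. Among the compounds with values here, the only guide is that compound 1, which carries a plain amine at the same position, gives 7.94 nM. A step from compound 2 to compound 3 that weakens binding beyond the scatter is therefore expected, estimated at a 50-fold higher number from compound 2 to compound 3 (1.70 log units; beyond the scatter). Compound 3 is expected to give 5 nM in this assay, within a range of 1 nM to 30 nM.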

Compound 3, inhibition constant: 0.251 nM
Beside the measured number, compound 3's estimate is 20-fold (1.30 log units) above it; measured number below the stated range.
By their numbers in this assay, from the lowest: compound 2; then compound 3; then compound 1.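

In this assay, replacing the ring-bearing group on the amine nitrogen with 2-methoxyethyl gives a 2.5-fold higher number from compound 2 to compound 3 (0.40 log units; beyond the scatter) and so counts as a modest change, even though it is beyond the usual scatter. This shows that the five-membered non-aromatic ring with its 2 hetero atoms is not essential for a low number at this position: a simple open chain with no ring and no hydrogen-bond donor leaves compound 3 at 0.251 nM, so two very different groups on this nitrogen both give strong binding. Nothing measured here accounts for how small the step is.

Compound 1 differs from compound 3 in more than one place, so its value cannot show what a plain amine would give on the shared core carrying the same sulfonyl-linked fluorophenyl group. Going by these compounds, it also remains open whether the oxygen of the 2-methoxyethyl group matters, which a plain propyl chain could test, and whether a longer chain such as 3-methoxypropyl would keep binding at a similar level.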